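The source may hold more compounds than are shown below. What is called first, only, known or untested is meant among the compounds shown, and "the series" means these compounds.

Compound 2 `Cc1cc(C)n2nc(SCc3nnc(SCc4cc(=O)c5ccccc5o4)n3N)nc2n1` in a functional assay on MCF7 cells (Homo sapiens) for cytotoxicity, read by MTT assay, with a stated time of 72 h (on this read-out lower numbers stand for stronger inhibition and higher numbers for weaker inhibition), gives > 25000 nM, which is a limit of the assay and not a number. Compound 1 `Cc1cc(C)n2nc(SCc3nnc(SCc4coc5ccccc5c4=O)n3-c3ccccc3)nc2n1` in this assay gives > 25000 nM, again a limit. Both values shown sit at this limit (the limit of > 25000 nM in this assay, at which 2 of the 2 values shown sit). Compound 3 `Cc1cc(C)n2nc(SCc3nnc(SCc4cc(=O)c5ccccc5o4)n3-c3ccccc3)nc2n1` is not yet measured; it differs from compound 2 by phenyl in place of amino on an aromatic nitrogen, in words phenyl in place of amino on an aromatic nitrogen. Within the data shown here, no step between measured compounds is available, so no shift beyond the scatter is expected from compound 2 to compound 3 in this assay, as compound 1 with the same phenyl also sits at > 25000 nM. The expected step is a step that the limit leaves unreadable from compound 2 to compound 3. Compound 3 is estimated at 40000 nM, range 15000 nM to 150000 nM, most likely reported as a limit again.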

Compound 3, half-maximal inhibitory concentration: > 25000 nM
Compound 3 gave a limit, no number; the forecaster's own chance of this, stated with the estimate: 85%; the middle value does not contradict the limit.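

No step can be read from compound 2 to compound 3 or from compound 1 to compound 3; each value is a limit, not a number: the limit of > 25000 nM in this assay, at which 3 of the 3 values shown sit.

From the compounds shown here alone, whether phenyl in place of amino changes the read-out at all stays open.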